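Swapping the amide substituent in compound 2 for a methylcyclopropyl

The compounds below may be only part of what the source reports. "The series", "measured", "known", "first", "only" and "open" are said of these compounds alone.

Compound 2, with the structure `CNC(=O)c1cc(C(=O)N[C@H]2[C@@H]3COC[C@@H]32)cc2c1OC[C@@]2(CO)c1ccccc1`, gives 2.4 in a physicochemical assay for lipophilicity, at pH 7.4; a lower number here means a more polar compound, a higher number a more lipophilic compound. Among the compounds with values here, compound 1, with the structure `CC[C@@]1(c2ccccc2)COc2c(C(=O)NC)cc(C(=O)N[C@H]3[C@@H]4COC[C@@H]43)cc21`, gives 4.2 in this assay, so compound 2 stands lower of the two, and the single step between them, a number 1.80 log units lower from compound 1 to compound 2 (beyond the scatter), is a large drop in lipophilicity. Compound 3, with the structure `CNC(=O)c1cc(C(=O)N[C@H]2C[C@@H]2C)cc2c1OC[C@@]2(CO)c1ccccc1`, has not yet been measured. It differs from compound 2 in one place: a group of 4 heavy atoms (4 carbon; one three-membered non-aromatic ring of carbon only) in place of a group of 6 heavy atoms (5 carbon, 1 oxygen; one three-membered non-aromatic ring of carbon only, one five-membered non-aromatic ring with 1 hetero atom), on an amide-type nitrogen. Within the data shown here, no measured step touches this position; the one known step concerns a different part of the molecule, the hydroxy in place of methyl on the saturated chain carbon, and it tells nothing directly about the amide substituent. What remains is the change itself, which removes one hydrogen-bond acceptor and one oxygen-containing five-membered ring and puts in a smaller all-carbon group, so compound 3 is expected to be more lipophilic than compound 2, with an upward step of about a number 0.90 log units higher from compound 2 to compound 3 (beyond the scatter). In this assay compound 3 is therefore estimated at 3.3, likely between 2.7 and 3.9.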

Compound 3, distribution coefficient: 3.3
Compound 3: the middle estimate sits on the measured number at the digits printed, within the range that was stated.
By their numbers in this assay, from the lowest: compound 2; then compound 3; then compound 1.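

The amide-type nitrogen is now shown to be a second place where the number in this assay moves: with the hydroxy-bearing core held constant, 2-methylcyclopropyl in place of the group of 6 heavy atoms gives a number 0.90 log units higher from compound 2 to compound 3 (beyond the scatter) on this read-out. This step is modest, whereas the earlier one at the other site of change, a number 1.80 log units lower from compound 1 to compound 2 (beyond the scatter), is large, so the two places do not shift the number equally for the particular exchanges shown. No measurement here separates the parts of the exchange at the amide nitrogen, such as the loss of the oxygen, the loss of the five-membered ring and the change in heavy atoms, and nothing measured accounts for the step.

The compounds shown leave open where an unsubstituted cyclopropyl, a tetrahydrofuranyl group or a longer alkyl chain on this nitrogen would fall in this assay, and so which of those parts matters most. They also leave open whether the same exchange on the core of compound 1 would give a step of similar size.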